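This account rests on a few compounds, and the source may have more. Where it says the series, first, only, none or still open, it means among the compounds named here.

Series notes. Compound 1 `Nc1ccccc1NC(=O)c1ccc(CSc2cccc(F)c2)cc1` gives 37.7% in a functional assay on A-375 cells (Homo sapiens) for inhibition, read by CCK-8 assay, with a stated time of 72 h, tested at 2 uM; a lower number here means less inhibition of growth, a higher number more inhibition of growth at the concentration tested. Compound 2 `Nc1ccccc1NC(=O)/C=C/c1ccc(CSc2ccc(C(F)(F)F)cn2)cc1` gives 10.3% in this assay. Compound 3 `Cc1cc(C)cc(SCc2ccc(C(=O)Nc3ccccc3N)cc2)c1` gives 48.5% in this assay. On these three numbers compound 3 stands highest; compound 1 is its nearest neighbour and compound 2 the furthest, both gaps beyond the scatter. Among the measured compounds shown here, the only step between measured compounds that differ in a single place is a number 10.8 percentage points higher from compound 1 to compound 3 (beyond the scatter), a modest move beyond the scatter, with 3,5-dimethylphenyl in place of 3-fluorophenyl on a sulfur.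

Compound 4 `Nc1ccccc1NC(=O)c1ccc(CSCCc2ccccc2)cc1` is not yet measured. Relative to compound 3 the difference is phenethyl in place of 3,5-dimethylphenyl on a sulfur. The two have the same atoms, joined differently. For the measured compounds named here, only the step from compound 1 to compound 3 bears on this, and loosely: there one aromatic group replaced another on the same sulfur, whereas the group entering compound 4 is a phenethyl rather than a substituted phenyl. Going by the values given here, no measured pair tests that kind of exchange. Given that the one relevant step was modest, a small downward step is expected for compound 4, a number 14.5 percentage points lower from compound 3 to compound 4 (beyond the scatter), with a real chance it stays within the scatter. The estimate for compound 4 in this assay is 34%, between 14% and 54%.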

Compound 4, percent growth inhibition at one concentration: 21.8%
The estimate for compound 4 lay 12.2 percentage points above the measured number; the measured number falls inside the stated range.
By their numbers in this assay, from the lowest: compound 2; then compound 4; then compound 1; then compound 3.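

Exchange on the sulfur now reaches beyond substituted phenyl groups: in this assay, phenethyl in place of 3,5-dimethylphenyl gives a number 26.7 percentage points lower from compound 3 to compound 4 (beyond the scatter), and phenethyl in place of 3-fluorophenyl gives a number 15.9 percentage points lower from compound 1 to compound 4 (beyond the scatter). Among the compounds shown here, both steps are beyond the scatter, so compound 4 stands below both compounds that carry a substituted phenyl on this sulfur, whereas the earlier step compared only two such phenyl groups. The change from compound 3 to compound 4 also leaves the counts printed for the group unchanged, so this drop goes with how the same atoms are joined rather than with any difference in those counts, and nothing measured here explains the drop.

The compounds shown do not separate the chain of phenethyl from the loss of a phenyl group sitting directly on the sulfur, and a benzyl group or a longer chain such as 3-phenylpropyl at this place would address that. As far as these compounds go, whether an unsubstituted phenyl or a chain ending in an amine, such as 2-aminoethyl, would hold the values of compound 1 and compound 3 also remains open.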